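Hydroxymethyl in place of carbamoyl on compound 2

The source may hold more compounds than are shown below. What is called first, only, known or untested is meant among the compounds shown, and "the series" means these compounds.

In an ADME assay on microsomes (Homo sapiens) for metabolic stability (on this read-out lower numbers stand for slow clearance and higher numbers for fast clearance), compound 1 `CNC(=O)[C@@H]1CCCN1S(=O)(=O)c1ccc(Cl)c(COc2cccc3c(-n4ccnc4)cc(C)nc23)c1Cl` gives 33.3 mL/min/kg, while compound 2 `Cc1cc(C(F)(F)F)c2cccc(OCc3c(Cl)ccc(S(=O)(=O)N4CCC[C@H]4C(N)=O)c3Cl)c2n1` gives 167 mL/min/kg, the higher of the two numbers, with a gap beyond the usual scatter. Compound 3 `Cc1cc(C(F)(F)F)c2cccc(OCc3c(Cl)ccc(S(=O)(=O)N4CCC[C@H]4CO)c3Cl)c2n1` departs from compound 2 at one place: hydroxymethyl in place of carbamoyl on a saturated ring carbon, next to the ring nitrogen. Going by the values given here, no measured pair carries this change, so the data offer no direct guide. No step beyond the scatter is therefore expected in this assay. The estimated move is a 1.0-fold lower number from compound 2 to compound 3 (0.02 log units; within the scatter). Compound 3 is expected at 160 mL/min/kg, with an estimated range of 80 mL/min/kg to 320 mL/min/kg.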

Compound 3, clearance: 250 mL/min/kg
Compound 3: the middle estimate sits 1.6-fold (0.19 log units) below what was measured; the range from low to high includes it.
By their numbers in this assay, from the lowest: compound 1; then compounds 2 and 3 (each within the scatter of the next).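

In this assay, putting hydroxymethyl in place of carbamoyl on the saturated ring carbon gives a 1.5-fold higher number from compound 2 to compound 3 (0.18 log units; within the scatter) and so does not separate the two groups at this place. With both groups, the read-out stays in the same range of fast clearance. No measurement here accounts for this outcome. On these data alone, whether an amine, a carboxylic acid or a longer chain on this ring carbon would give a step beyond the scatter remains open. So does whether hydroxymethyl would behave the same way on the core of compound 1 .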